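The source may hold more compounds than are shown below. What is called first, only, known or untested is meant among the compounds shown, and "the series" means these compounds.

In a functional assay on MGC-803 cells (Homo sapiens) for inhibition, read by MTT assay, with a stated time of 48 h (on this read-out lower numbers stand for stronger inhibition and higher numbers for weaker inhibition), three compounds have been measured. Compound 1 `COc1ccc(CN(c2cc(OC)c(OC)c(OC)c2)S(=O)(=O)c2ccc(C)cc2)cc1` gives 4340 nM, and compound 2 `COc1cc(N(Cc2cccc(C)c2)S(=O)(=O)c2ccc(C)cc2)cc(OC)c1OC` gives 4340 nM. These two differ only in the aryl group carried by the saturated chain carbon on the sulfonamide nitrogen, and the step of no change at the digits printed from compound 1 to compound 2 (within the scatter) shows that this exchange leaves the result unchanged. Compound 3 `Cc1ccc(S(=O)(=O)N(Cc2nc3ccccc3[nH]2)c2ccc(F)cc2)cc1` gives 34600 nM, the highest of the three numbers and therefore the weakest inhibitor measured so far: compound 1 and compound 2 each sit well beyond the scatter below it.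

Compound 4 `COc1ccc(N(Cc2nc3ccccc3[nH]2)S(=O)(=O)c2ccc(C)cc2)cc1OC` is not yet measured. It differs from compound 3 in one place: 3,4-dimethoxyphenyl in place of 4-fluorophenyl on a sulfonamide nitrogen. For the measured compounds named here, no measured step covers this exchange, since the only step available alters the group on the chain carbon, not the group on the nitrogen. What can be said is that compound 1 and compound 2, which both carry a methoxy-bearing aryl on the nitrogen, come out stronger than compound 3 with its fluorophenyl. On that basis a step towards a lower number is expected in this assay, with the size estimated as a 2.9-fold lower number from compound 3 to compound 4 (0.46 log units; beyond the scatter) but quite uncertain. Compound 4 is therefore expected to give about 12000 nM, most likely between 4000 nM and 36000 nM.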

Compound 4, half-maximal inhibitory concentration: > 50000 nM
Compound 4: a limit, no number (the forecaster's own chance of this, stated with the estimate: 5%); middle value at least 4.1-fold (0.61 log units) away from the limit.
By their numbers in this assay, from the lowest: compounds 1 and 2 (each within the scatter of the next); then compound 3. At a limit, above all of these: compound 4.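

For the compounds shown here, until now no step touched the group on the sulfonamide nitrogen; in this assay, putting 3,4-dimethoxyphenyl in place of 4-fluorophenyl there gives an at least 1.4-fold higher number from compound 3 to compound 4 (0.15 log units; that floor lies within the scatter). Going by these compounds alone, on this core, then, the 3,4-dimethoxyphenyl group brings no gain in inhibition over 4-fluorophenyl, the first direct reading of what an exchange at this position does, although the floor of the step lies within the scatter and so does not by itself prove that the number truly rises. Compound 4 stands at a limit of the assay and not at a number: the limit of > 50000 nM in this assay, at which 1 of the 4 values shown sits.

From the compounds shown here alone, how far compound 4 really lies from compound 3 stays open, so the size of this step is unknown and only its lower bound can be stated. Also open, going by these compounds, is what other groups on the sulfonamide nitrogen would do on this same core, for instance a phenyl ring carrying an amine or a carboxylic acid, and whether any of them would bring the number down rather than up.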